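The compounds below may be only part of what the source reports. "The series", "measured", "known", "first", "only" and "open" are said of these compounds alone.

Going by the values given here, compound 2 `CN(C)CCC1=C(Cc2ccccn2)c2ccccc2C1` gives 3630 nM in an assay on CHO-K1 cells for binding affinity to muscarinic acetylcholine receptor M5 (Homo sapiens) (on this read-out lower numbers stand for stronger inhibition and higher numbers for weaker inhibition), the higher of the two numbers measured so far; compound 1 `CCCC(C1=C(CCN(C)C)Cc2ccccc21)c1ccccn1` gives 302 nM, and a 12-fold higher number from compound 1 to compound 2 (1.08 log units; beyond the scatter) is the only measured step. Compound 3 `CN(C)CCC1=C(Cc2cccnc2)c2ccccc2C1` differs from compound 2 by pyridin-3-yl in place of pyridin-2-yl on a saturated chain carbon bound to a double-bonded ring carbon. Among the compounds with values here, the one measured step concerns propyl against hydrogen and does not bear on an exchange of pyridin-2-yl for pyridin-3-yl, so nothing measured here speaks to this change. No step beyond the scatter is therefore expected for compound 3, no change at the digits printed from compound 2 to compound 3 (within the scatter). Compound 3 is estimated at 3630 nM, within the range 1200 nM to 11000 nM.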

Compound 3, inhibition constant: 7940 nM
Beside the measured number, compound 3's estimate is 2.2-fold (0.34 log units) below it; low and high end bracket the measured number.
By their numbers in this assay, from the lowest: compound 1; then compound 2; then compound 3.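

Even with the same atoms, the exchange of pyridin-2-yl for pyridin-3-yl on this saturated chain carbon registers in this assay, giving a 2.2-fold higher number from compound 2 to compound 3 (0.34 log units; beyond the scatter). The position therefore responds to the identity of the pyridine attachment as well as to the propyl group, although this step is modest. Nothing available accounts for the difference. The compounds shown leave open how pyridin-4-yl or phenyl would read at this place. They also leave open whether propyl on the same chain carbon would lower the number alongside pyridin-3-yl as it does alongside pyridin-2-yl.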